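The source may report more compounds than this note shows. Statements on the series, on what has been measured and on what is new or still open speak of the compounds shown alone.

Measured so far in an assay on HEK293 cells for displacement of a labelled ligand from NPC1-like intracellular cholesterol transporter 1 (Homo sapiens); a lower number here means a stronger inhibitor, a higher number a weaker inhibitor:
compound 1, `CC(C)(C)c1ccc(C(=O)N2CCC3(CC2)C(=O)N(CC(=O)N2CCNCC2)CN3c2ccccc2)cc1`, 22000 nM
compound 2, `CC(C)(C)c1ccc(C(=O)N2CCC3(CC2)C(=O)N(CC(=O)N2CCCC(O)C2)CN3c2ccccc2)cc1`, 12200 nM
compound 3, `CC(C)(C)c1ccc(C(=O)N2CCC3(CC2)C(=O)N(CC(=O)N2CCC(CCO)CC2)CN3c2ccccc2)cc1`, 2600 nM

The three share one core and differ only in the group on the carbonyl carbon of the side chain. Compound 3 stands lowest of the three in this assay: a 4.7-fold lower number from compound 2 to compound 3 (0.67 log units; beyond the scatter) and an 8.5-fold lower number from compound 1 to compound 3 (0.93 log units; beyond the scatter) are both beyond the scatter, while a 1.8-fold lower number from compound 1 to compound 2 (0.26 log units; within the scatter) stays within it.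

Compound 4, `CC(C)(C)c1ccc(C(=O)N2CCC3(CC2)C(=O)N(CC(=O)NCCCNS(C)(=O)=O)CN3c2ccccc2)cc1`, is not yet measured. Against compound 3 the change is (3-(methanesulfonamido)propyl)amino in place of 4-(2-hydroxyethyl)piperidin-1-yl on a carbonyl carbon. Among the measured compounds shown here, the steps that bear on it are the two ending at compound 3, as both also exchange the group on that carbonyl carbon; they show that this position moves this assay by a modest amount, and compound 3 carries the variant with the lowest number. For the measured compounds named here, no measured step removes the ring altogether or brings in an open chain, so the direction of the present change rests on little. Compound 3 holds the lowest number, and the other two variants at this position sit higher. Compound 4 is therefore expected to give a higher number than compound 3, with a 3.1-fold higher number from compound 3 to compound 4 (0.49 log units; beyond the scatter) as the expected step. The estimate for compound 4 in this assay is 8000 nM, within 2500 nM to 25000 nM.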

Compound 4, half-maximal inhibitory concentration: 10400 nM
Beside the measured number, compound 4's estimate is 1.3-fold (0.11 log units) below it, and the stated range covers the measured number.
By their numbers in this assay, from the lowest: compound 3; then compounds 4, 2 and 1 (each within the scatter of the next, the first and the last beyond it).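

In this assay, among the compounds shown here, (3-(methanesulfonamido)propyl)amino is the first group at this position with no ring, and a 4.0-fold higher number from compound 3 to compound 4 (0.60 log units; beyond the scatter) shows that this exchange for 4-(2-hydroxyethyl)piperidin-1-yl, with 9 heavy atoms on each side, does not hold the number of compound 3. For the compounds shown here, the open chain is not separated from one ring-bearing variant, as a 1.2-fold lower number from compound 2 to compound 4 (0.07 log units; within the scatter) stays within the scatter, while a 2.1-fold lower number from compound 1 to compound 4 (0.33 log units; beyond the scatter) lies beyond it, so a ring on this carbonyl carbon is not required to match 3-hydroxypiperidin-1-yl, and compound 3 remains the only compound whose steps to all the others are beyond the scatter. No measurement at hand accounts for any of these differences.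

Going by these compounds, whether the lower number of compound 3 goes with the piperidine ring or with its 2-hydroxyethyl chain stays open, and plain piperidin-1-yl or 4-(2-methoxyethyl)piperidin-1-yl on the same carbonyl carbon would separate the two. On the open-chain side, the compounds shown leave open how a 3-hydroxypropylamino group, a longer chain ending in the methanesulfonamide, or a chain ending in a carboxylic acid would read in this assay.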